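The source may report more compounds than this note shows. Statements on the series, on what has been measured and on what is new or still open speak of the compounds shown alone.

In an ADME assay on Vero cells (Chlorocebus sabaeus) for cytotoxicity, read by CellTiter-Glo, with a stated time of 72 h (a higher number here means that more compound is tolerated, a lower number that less compound is tolerated), compound 1 (`CCNc1n[n+]([O-])c2cc(Br)ccc2[n+]1[O-]`) gives 4.2 ug/mL and compound 2 (`[O-][n+]1nc(NC2CCC2)[n+]([O-])c2ccc(Br)cc21`) gives 3.8 ug/mL. These two numbers lie within the scatter of each other, so compound 2 has no distinct rank in this short series. Compound 3 (`[O-][n+]1nc(N[C@@H]2C[C@H]3CC[C@@H]2C3)[n+]([O-])c2ccc(Br)cc21`) differs from compound 2 in one place: a group of 7 heavy atoms (7 carbon; 2 five-membered non-aromatic rings of carbon only) in place of a group of 4 heavy atoms (4 carbon; one four-membered non-aromatic ring of carbon only), on a nitrogen on an aromatic ring. Among the measured compounds shown here, only one measured step bears on this change, and it sits at the same place: a 1.1-fold lower number from compound 1 to compound 2 (0.04 log units; within the scatter). For the measured compounds named here, that is thin support, as no measured compound carries a group of this size or a group with two rings. Even so, the step gives no ground to expect a clear shift in this assay, in either direction. The expected change is a 1.1-fold lower number from compound 2 to compound 3 (0.04 log units; within the scatter), which would be no step beyond the scatter. For compound 3 the estimated value is 3.5 ug/mL, with an expected range from 1.6 ug/mL to 7.5 ug/mL.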

Compound 3, half-maximal cytotoxic concentration: 0.8 ug/mL
Estimate against measurement, compound 3: 4.4-fold (0.64 log units) above; measured number outside the range, below it.
By their numbers in this assay, from the lowest: compound 3; then compounds 2 and 1 (each within the scatter of the next).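

In this assay the group on the nitrogen on an aromatic ring proves able to move the number, which the ethyl and cyclobutyl pair alone did not show: the group of 7 heavy atoms with 2 five-membered non-aromatic rings gives a 4.8-fold lower number from compound 2 to compound 3 (0.68 log units; beyond the scatter) and, against ethyl, a 5.3-fold lower number from compound 1 to compound 3 (0.72 log units; beyond the scatter). Less compound is thus tolerated with this group in place than with either smaller group on the shared core. No measurement at hand accounts for this drop.

Three compounds cannot separate the count of heavy atoms, the second ring and the 3 defined stereocentres as the feature that goes with the lower number. Going by these compounds, a one-ring cyclohexyl, a longer open chain, another stereoisomer of the same group, or a group carrying an amine or a carboxylic acid at this place remains open.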